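From 4-fluorophenyl to naphthalen-1-yl on sulfur

The source may hold more compounds than are shown below. What is called first, only, known or untested is meant among the compounds shown, and "the series" means these compounds.

Compound 1 `Nc1ccccc1NC(=O)/C=C/c1ccc(CSc2cccc(F)c2)cc1` gives 7.95%
Compound 2 `Nc1ccccc1NC(=O)/C=C/c1ccc(CSc2ccc(C(F)(F)F)cn2)cc1` gives 4.42%
Compound 3 `Nc1ccccc1NC(=O)/C=C/c1ccc(CSc2ccc(F)cc2)cc1` gives 14.1%

These numbers come from a functional assay on HCT-116 cells (Homo sapiens) for inhibition, read by CCK-8 assay, with a stated time of 72 h, tested at 2 uM (a higher number here means more inhibition of growth at the concentration tested, a lower number less inhibition of growth), and sit close together. Compound 3 lies within the scatter of both others (a number 6.2 percentage points higher from compound 1 to compound 3 (within the scatter); a number 9.7 percentage points higher from compound 2 to compound 3 (within the scatter)), and the remaining pair behaves alike (a number 3.5 percentage points lower from compound 1 to compound 2 (within the scatter)). Compound 4 `Nc1ccccc1NC(=O)/C=C/c1ccc(CSc2cccc3ccccc23)cc1` carries naphthalen-1-yl in place of 4-fluorophenyl on a sulfur. Among the measured compounds shown here, none of the measured steps introduces naphthalen-1-yl, so they guide only loosely, but every swap on this sulfur so far stayed within the scatter. No step beyond the scatter is therefore expected, and the estimated change is small (a number 3.1 percentage points lower from compound 3 to compound 4 (within the scatter)). The expected value for compound 4 is 11% (estimated range 3% to 28%).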

Compound 4, percent growth inhibition at one concentration: 11%
Compound 4: middle estimate and measured number agree at the digits printed; the measured number falls inside the stated range.
By their numbers in this assay, from the lowest: compounds 2, 1, 4 and 3 (each within the scatter of the next).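

Among the compounds shown here, putting naphthalen-1-yl, with its two aromatic rings, on the sulfur gives no step beyond the scatter in this assay against any earlier group (from the single ring of compound 3: a number 3.1 percentage points lower from compound 3 to compound 4 (within the scatter); from compound 1: a number 3.1 percentage points higher from compound 1 to compound 4 (within the scatter); from compound 2: a number 6.6 percentage points higher from compound 2 to compound 4 (within the scatter)). This position therefore tolerates two fused aromatic rings as well as one, and all four compounds remain close together. No measurement here explains this flat result. Still open, as far as these compounds go, is whether an amine, a carboxylic acid or a longer chain on the sulfur would give a clear step.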